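Aryl swap on the sulfonamide nitrogen: compound 2 to compound 3

A few compounds are considered here, and "the series" means these few. Any claim that something is new, unique, unknown or untested is made for them only; others in the source may bear on it.

In a functional assay on cells (leukaemia cell line, Homo sapiens) for inhibition, read by sulforhodamine B assay, with a stated time of 48 h (a lower number here means a stronger inhibitor of growth, a higher number a weaker inhibitor of growth), compound 1 `O=S(=O)(Nc1ccccc1Cl)c1ccc(-c2cnc(C3CC3)o2)cc1` gives 49700 nM and compound 2 `O=S(=O)(Nc1ccc(Br)c(Cl)c1)c1ccc(-c2cnc(C3CC3)o2)cc1` gives 70300 nM. Going by the values given here, compound 2 holds the highest of only two numbers, but it stands within the scatter of compound 1, so the two cannot be ranked. Compound 3 `O=S(=O)(Nc1cc(F)cc(F)c1)c1ccc(-c2cnc(C3CC3)o2)cc1` follows from compound 2 by 3,5-difluorophenyl in place of 4-bromo-3-chlorophenyl on a sulfonamide nitrogen, with 3,5-difluorophenyl in place of 4-bromo-3-chlorophenyl on a sulfonamide nitrogen. Among the compounds with values here, one measured step bears on this, a change at the same nitrogen: a 1.4-fold higher number from compound 1 to compound 2 (0.15 log units; within the scatter). It stays within the scatter, and a single step is thin evidence, so no shift beyond the scatter is expected in this assay, in either direction. The expected change is a 1.3-fold lower number from compound 2 to compound 3 (0.11 log units; within the scatter). Compound 3 is estimated at 55000 nM, with an expected range of 25000 nM to 100000 nM.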

Compound 3, concentration for total growth inhibition: 80000 nM
Estimate against measurement, compound 3: 1.5-fold (0.16 log units) below, within the range that was stated.
By their numbers in this assay, from the lowest: compounds 1, 2 and 3 (each within the scatter of the next).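

In this assay the new aryl group gives a 1.1-fold higher number from compound 2 to compound 3 (0.06 log units; within the scatter) and also a 1.6-fold higher number from compound 1 to compound 3 (0.21 log units; within the scatter), so neither step separates the compounds. Going by these compounds alone, with 2-chlorophenyl, 4-bromo-3-chlorophenyl and 3,5-difluorophenyl on the sulfonamide nitrogen, these three compounds now show that this position tolerates a change in which halogens the ring carries and where they stand, and no step among them lies beyond the scatter. Nothing available accounts for this flat result.

From the compounds shown here alone, all three groups on this nitrogen are halogen-bearing phenyl rings, so it remains open whether a carboxylic acid, an amine or a longer alkyl chain at this position would give a step beyond the scatter. The rest of the shared core is constant, so these compounds say nothing about changes there.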